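A few compounds are considered here, and "the series" means these few. Any claim that something is new, unique, unknown or untested is made for them only; others in the source may bear on it.

Measured compounds:

Compound 1, `Cc1ccc2nc(/N=C3\C(=O)N(CN(c4ccccc4)c4ccccc4)c4cccc(Cl)c43)sc2c1`: in a functional assay on MDA-MB-231 cells (Homo sapiens) for cytotoxicity, read by sulforhodamine B assay, with a stated time of 48 h (a higher number here means a weaker inhibitor of growth, a lower number a stronger inhibitor of growth), compound 1 gives 54000 nM.
Compound 2, `Cc1ccc2nc(/N=C3\C(=O)N(CN(C)C)c4ccccc43)sc2c1`: in this assay compound 2 gives 19200 nM.
Compound 3, `Cc1ccc2nc(/N=C3\C(=O)N(CN(C)C)c4cccc(Cl)c43)sc2c1`: in this assay compound 3 gives 10900 nM.

Compound 1 carries the highest of the three numbers, and its gaps to compound 2 and to compound 3 are both beyond the scatter. The difference between the core of compound 1 and the core of compound 3 is not broken down here.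

Compounds 3 and 2 differ in one place, (hydrogen in place of chloro on an aromatic carbon), and that step, a 1.8-fold higher number from compound 3 to compound 2 (0.25 log units; within the scatter), leaves the two values within the scatter of each other, so nothing can be read into their order.

Compound 4, `Cc1ccc2nc(/N=C3\C(=O)N(CN(c4ccccc4)c4ccccc4)c4ccccc43)sc2c1`, has not yet been measured in this assay. For the measured compounds named here, it differs from compound 1 in the same kind of change, (hydrogen in place of chloro on an aromatic carbon), so the pair of compounds 3 and 2 is the only guide available. Since compound 3 and compound 2 lie within the scatter of each other after a 1.8-fold higher number from compound 3 to compound 2 (0.25 log units; within the scatter), compound 4 is expected to sit close to compound 1, with perhaps a slight drift to a higher number; the expected step is a 1.4-fold higher number from compound 1 to compound 4 (0.14 log units; within the scatter). On that basis compound 4 is estimated at 75000 nM, expected to fall between 35000 nM and 160000 nM, and there is some chance the measurement returns only a limit.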

Compound 4, concentration for 50% growth inhibition: 34100 nM
Beside the measured number, compound 4's estimate is 2.2-fold (0.34 log units) above it; the whole stated range lies above it.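

Replacing chloro with hydrogen on the aromatic carbon gives a 1.6-fold lower number from compound 1 to compound 4 (0.20 log units; within the scatter) in this assay, so this pair on its own shows no separation that can be read. Set beside the same change on the core of compound 3, the step shows that the effect of this change cannot be assumed to transfer unaltered from one core to the other, as the two steps differ by more than the scatter of two such steps: the same change on two cores in this assay, a 1.8-fold higher number (0.25 log units; within the scatter) from compound 3 to compound 2 and a 1.6-fold lower number (0.20 log units; within the scatter) from compound 1 to compound 4, 2.8-fold (0.45 log units) apart, beyond the scatter of two such steps

This does not show that chloro favours or disfavours growth inhibition on either core, as each step taken alone lies within the scatter, and two cores are too few to support a rule for the series or to say which part of the core sets the difference.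

The compounds shown leave open how fluoro, bromo or methoxy on that same aromatic carbon would read on either core, which would test whether the mismatch is particular to chloro. They also leave open whether a third core, for example one carrying morpholine in place of the dimethylamino or diphenylamino group, would follow the pair of compound 3 and compound 2 or the pair of compound 1 and compound 4.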